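The source may report more compounds than this note shows. Statements on the series, on what has been measured and on what is new or still open speak of the compounds shown alone.

Among the compounds with values here, compound 2 `CCOC(=O)c1cc2cc(/C=C/C(=O)c3ccc(C)cc3)cc(C(C)CC)c2oc1=O` is the only compound with a number in a functional assay on MCF7 cells (Homo sapiens) for cytotoxicity, read by sulforhodamine B assay, with a stated time of 48 h (a higher number here means a weaker inhibitor, a lower number a stronger inhibitor), where compound 2 gives 81100 nM. Compound 1 `CCC(C)c1cc(/C=C/C(=O)c2ccc(Cl)cc2)cc2cc(C(C)=O)c(=O)oc12`, which also carries a chloro, gives "not active" (no number reported) in this assay, with no number reported. Compound 3 `CCOC(=O)c1cc2cc(/C=C/C(=O)c3ccc(Cl)cc3)cc(C(C)CC)c2oc1=O` differs from compound 2 by chloro in place of methyl on an aromatic carbon. Within the data shown here, no measured pair shows this change, so its size is open; since compound 1 gives "not active" (no number reported), a step within the scatter or a modest loss is expected, a 1.2-fold higher number from compound 2 to compound 3 (0.07 log units; within the scatter). Compound 3 is accordingly estimated at 95000 nM, within 30000 nM to 300000 nM.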

Compound 3, half-maximal inhibitory concentration: 11100 nM
Compound 3: the middle estimate sits 8.6-fold (0.93 log units) above what was measured, and the stated range ends above it.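

In this assay, within the data shown here, the change from 4-methylphenyl to 4-chlorophenyl gives the first readable step: a 7.3-fold lower number from compound 2 to compound 3 (0.86 log units; beyond the scatter). The chloro alone does not decide the outcome, since compound 3 has a number while compound 1, which also carries a chloro, gives "not active" (no number reported). Nothing available here accounts for the step. As far as these compounds go, whether a fluoro or a methoxy at this place would move the number the same way remains open. So does how an amine there would compare with chloro and methyl.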